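Nitro to Amino in a Cytotoxic Series

This account rests on a few compounds, and the source may have more. Where it says the series, first, only, none or still open, it means among the compounds named here.

In a functional assay on Bel-7402 cells (Homo sapiens) for cytotoxicity, read by MTT assay, with a stated time of 48 h (a higher number here means a weaker inhibitor, a lower number a stronger inhibitor), compound 1 `CCn1cc(-c2nc3ccccc3o2)c(=O)c2cc(F)c(N3CCNCC3)nc21` gives 16800 nM and compound 2 `CCn1cc(-c2nc3ccccc3s2)c(=O)c2cc(F)c(N3CCNCC3)nc21` gives 2400 nM. Compound 3 `CCn1cc(-c2nc3ccc([N+](=O)[O-])cc3[nH]2)c(=O)c2cc(F)c(N3CCNCC3)nc21` gives 10800 nM, which lies within the scatter of compound 1 and is a higher number, so a weaker result, than that of compound 2.

Compound 4 `CCn1cc(-c2nc3ccc(N)cc3[nH]2)c(=O)c2cc(F)c(N3CCNCC3)nc21` carries amino in place of nitro on an aromatic carbon of the six-membered aromatic ring of carbon only: amino in place of nitro on an aromatic carbon.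

Among the compounds with values here, the only measured step, a 7.0-fold lower number from compound 1 to compound 2 (0.85 log units; beyond the scatter), exchanges a different group in a different place. It shows that one exchange on the shared core can move the number beyond the scatter, but it gives neither size nor direction for this change. Within the data shown here, no measured step touches the nitro group, so the estimate starts from compound 3 at 10800 nM and no step beyond the scatter is expected in this assay. The estimated step is a 1.2-fold lower number from compound 3 to compound 4 (0.08 log units; within the scatter). For compound 4 the expected value is 9000 nM, with an estimated range from 3000 nM to 27000 nM.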

Compound 4, half-maximal inhibitory concentration: 93300 nM
Compound 4: the middle estimate sits 10-fold (1.02 log units) below what was measured; the whole stated range lies below it.
By their numbers in this assay, from the lowest: compound 2; then compounds 3 and 1 (each within the scatter of the next); then compound 4.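

In this assay, the change at this carbon gives an 8.6-fold higher number from compound 3 to compound 4 (0.94 log units; beyond the scatter), so amino in place of nitro gives a weaker result and the substituent here matters to the read-out. Within the data shown here, the earlier compounds could not show this, as their only measured step lay in a different place and none of them varied the group on this carbon. In this assay, exchanging the whole group that carries this carbon, a group of 10 heavy atoms in place of a group of 9 heavy atoms on an aromatic carbon of the shared core, gives a 39-fold higher number from compound 2 to compound 4 (1.59 log units; beyond the scatter) and a 5.6-fold higher number from compound 1 to compound 4 (0.74 log units; beyond the scatter).

No evidence is available on why the number rises with this exchange. From the compounds shown here alone, it also remains open whether nitro favours the result or amino disfavours it, and how a methoxy group, a chlorine atom or an acetamide on the same carbon would compare.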